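A few compounds are considered here, and "the series" means these few. Any claim that something is new, unique, unknown or untested is made for them only; others in the source may bear on it.

Measured so far:
Compound 1, `CSCC/C=N/Nc1nc(N)c2ncn([C@@H]3O[C@H](CO)[C@@H](O)[C@H]3O)c2n1`, gives 0% in an assay on CHO-K1 cells for displacement of a labelled ligand from adenosine receptor A1 (Homo sapiens), read by scintillation counting, with a stated time of 60 min, tested at 1 uM; a lower number here means less inhibition, a higher number more inhibition at the concentration tested (going by the name of the read-out).
Compound 2, `Nc1nc(N/N=C/c2ccc(C(F)(F)F)cc2C(F)(F)F)nc2c1ncn2[C@@H]1O[C@H](CO)[C@@H](O)[C@H]1O`, gives 0% in this assay.
Compound 3, `Nc1nc(N/N=C/c2ccc(N(c3ccccc3)c3ccccc3)cc2)nc2c1ncn2[C@@H]1O[C@H](CO)[C@@H](O)[C@H]1O`, gives 0% in this assay.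

Compound 1 stands level with compounds 2 and 3 at the digits shown: its nearest neighbour is compound 2 and its furthest compound 3, and both gaps lie within the scatter, so no order among the three can be stated. Compound 4 is `Nc1nc(N/N=C/c2ccc(-n3ccnc3)cc2)nc2c1ncn2[C@@H]1O[C@H](CO)[C@@H](O)[C@H]1O`; it differs from compound 1 as follows: 4-(1H-imidazol-1-yl)phenyl in place of 2-(methylsulfanyl)ethyl on a carbon with a double bond to nitrogen. Among the measured compounds shown here, no step between measured compounds is available for this change. Compounds 2 and 3 each bear an aromatic group in place of the chain, and in this assay compound 2 gives 0% while compound 3 gives 0%. The step of no change at the digits printed from compound 1 to compound 4 (within the scatter) is therefore expected to be none beyond the scatter. Compound 4 is estimated at 0%, with a range from -8% to 12%.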

Compound 4, a percentage reported as inhibition, at one concentration (the size of the read-out at that concentration, not a potency): 0%
Estimate against measurement, compound 4: no gap at the digits printed; measured number inside the range.
By their numbers in this assay, from the lowest: compounds 1, 2, 3 and 4 (each within the scatter of the next).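

In this assay, putting 4-(1H-imidazol-1-yl)phenyl in place of 2-(methylsulfanyl)ethyl on a carbon with a double bond to nitrogen gives no change at the digits printed from compound 1 to compound 4 (within the scatter). Among the compounds shown here, this is the only step that can be read at this position, and it shows that exchanging the open chain for this two-ring aromatic group does not move inhibition beyond the scatter at the concentration tested. No measured property bears on this result. As far as these compounds go, all four compounds print the same value, so whether any group on this carbon can raise inhibition stays open. A carboxylic acid, an amine or a longer chain there remains untested in the compounds shown.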